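The source may report more compounds than this note shows. Statements on the series, on what has been measured and on what is new or still open speak of the compounds shown alone.

The study concerns two measured compounds and one awaiting measurement in an in vitro functional assay on cells for agonist activity at Bombesin receptor subtype-3 (Mus musculus), read by luminescence and calcium flux; on this read-out higher numbers stand for an effect only at larger amounts of compound and lower numbers for an effect already at smaller amounts. Compound 1 `Cc1ccccc1Cc1cnc(CCc2ccc(-c3ccccc3C(=O)O)cc2)[nH]1` gives in this assay a value of 9.3 nM. Compound 2 `N#Cc1cccc(Cc2cnc(CCc3ccc(-c4ccccc4C(=O)O)cc3)[nH]2)c1` gives 20 nM in this assay. Among the measured compounds shown here, the one measured step, a 2.2-fold higher number from compound 1 to compound 2 (0.33 log units; beyond the scatter), exchanged one group on a saturated chain carbon bound to an aromatic carbon. For the measured compounds named here, compound 2 thus stands as the highest of the two numbers, with compound 1 its only neighbour, lower by that same step. Compound 3 `O=C(O)c1ccccc1-c1ccc(CCc2ncc(Cc3ccc(F)cc3)[nH]2)cc1` differs from compound 2 by 4-fluorophenyl in place of 3-cyanophenyl on a saturated chain carbon bound to an aromatic carbon. Going by the values given here, only the step from compound 1 to compound 2 bears on this change, as it altered the same group at the same place. That step was modest, and it ran from a 2-methylphenyl to the 3-cyanophenyl that now leaves. Nothing measured here speaks to 4-fluorophenyl directly, so the expectation is a step of similar modest size in either direction or none beyond the scatter. The step expected for compound 3 is a 1.4-fold lower number from compound 2 to compound 3 (0.15 log units; within the scatter). Compound 3 is therefore estimated at 14 nM, with a range from 5 nM to 40 nM.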

Compound 3, half-maximal effective concentration: 50 nM
Estimate against measurement, compound 3: 3.6-fold (0.55 log units) below, and the stated range ends below it.
By their numbers in this assay, from the lowest: compound 1; then compound 2; then compound 3.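

In this assay the exchange of 3-cyanophenyl for 4-fluorophenyl on a saturated chain carbon bound to an aromatic carbon gave a 2.5-fold higher number from compound 2 to compound 3 (0.40 log units; beyond the scatter) and thus showed that a second change of group at this place also moves the number beyond the scatter, in the same direction as the first step. Measured against the 2-methylphenyl group of compound 1, the 4-fluorophenyl group gave a 5.4-fold higher number from compound 1 to compound 3 (0.73 log units; beyond the scatter) and so produced the widest gap yet seen at this place, with the 2-methylphenyl group still holding the lowest number of the three. The data at hand offer no explanation for these differences.

The three groups differ both in their substituent and in where their names place it on the phenyl ring, so the compounds shown cannot separate these two changes. Open too, from the compounds shown here alone, is how an unsubstituted phenyl, 2-fluorophenyl or 3-fluorophenyl group would compare at this place, and whether a cyclohexyl ring would be tolerated there at all.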